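Removing the hydroxy from the benzyl amide: compound 4

The compounds below may be only part of what the source reports. "The series", "measured", "known", "first", "only" and "open" are said of these compounds alone.

Compound 1, `CC1=C(/C=C/C(C)=C/C=C/C(C)=C\C(=O)Nc2ccccc2)C(C)(C)CCC1n1ccnc1`, in a functional assay on CWR22R cells (Homo sapiens) for inhibition, read by MTT assay (on this read-out lower numbers stand for stronger inhibition of growth and higher numbers for weaker inhibition of growth), gives 1280 nM.
Compound 2, `CC1=C(/C=C/C(C)=C/C=C/C(C)=C\C(=O)Nc2ccc(O)cc2)C(C)(C)CCC1n1ccnc1`, in this assay gives 3890 nM.
Compound 3, `CC1=C(/C=C/C(C)=C/C=C/C(C)=C\C(=O)NCc2ccc(O)cc2)C(C)(C)CCC1n1ccnc1`, in this assay gives 1860 nM.

The three measured compounds share one core and differ only in the group on the amide-type nitrogen. Between compound 2 and compound 1 the change is hydrogen in place of hydroxy on an aromatic carbon; it gave a 3.0-fold lower number from compound 2 to compound 1 (0.48 log units; beyond the scatter). Between compound 1 and compound 3 the step is a 1.5-fold higher number from compound 1 to compound 3 (0.16 log units; within the scatter), so these two values cannot be ordered. Between compound 2 and compound 3 the change is 4-hydroxybenzyl in place of 4-hydroxyphenyl on an amide-type nitrogen, with a 2.1-fold lower number from compound 2 to compound 3 (0.32 log units; beyond the scatter).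

Compound 4, `CC1=C(/C=C/C(C)=C/C=C/C(C)=C\C(=O)NCc2ccccc2)C(C)(C)CCC1n1ccnc1`, is not yet measured in this assay. It differs from compound 3 by hydrogen in place of hydroxy on an aromatic carbon. This is the same change as from compound 2 to compound 1, and the place is described in the same words; what differs around it is told by 4-hydroxybenzyl in place of 4-hydroxyphenyl on an amide-type nitrogen, the group carrying the ring being 4-hydroxybenzyl rather than 4-hydroxyphenyl. For the measured compounds named here, with only one earlier instance, on a differently linked ring, the transfer is uncertain.

Going by the values given here, the expected step for compound 4 is a 2.5-fold lower number from compound 3 to compound 4 (0.39 log units; beyond the scatter), set beside the earlier one because a 3.0-fold lower number from compound 2 to compound 1 (0.48 log units; beyond the scatter) is the only comparable step available, and damped because a 1.5-fold higher number from compound 1 to compound 3 (0.16 log units; within the scatter) shows the two linkers behaving alike so far. For compound 4 in this assay the estimate is 750 nM, between 350 nM and 1600 nM.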

Compound 4, concentration for 50% growth inhibition: > 100000 nM
Compound 4: only a limit was reported (the forecaster's own chance of this, stated with the estimate: 2%); middle value at least 130-fold (2.12 log units) from the limit.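

In this assay compound 4 gives > 100000 nM, which is a limit of the assay and not a number. With an at least 53-fold higher number from compound 3 to compound 4 (1.73 log units; beyond the scatter), hydrogen in place of hydroxy on an aromatic carbon does not carry over from the 4-hydroxyphenyl amide to the 4-hydroxybenzyl amide, in either direction or size: the same change on two cores in this assay, a 3.0-fold lower number (0.48 log units; beyond the scatter) from compound 2 to compound 1 and an at least 53-fold higher number (1.73 log units; beyond the scatter) from compound 3 to compound 4, at least 160-fold (2.21 log units) apart, beyond the scatter of two such steps. Compound 4 also stands apart from the two anilide-type compounds, with an at least 25-fold higher number from compound 2 to compound 4 (1.41 log units; beyond the scatter) and an at least 78-fold higher number from compound 1 to compound 4 (1.89 log units; beyond the scatter), but this rests on one pair for each linker and a step bounded on one side only, so it shows that the effect of this change depends on the core here and does not show why, or how large the step on the benzyl core really is.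

Open, as far as these compounds go, is whether the result belongs to the bare benzyl group alone, or whether a methoxy, fluoro or amino group in place of the hydroxy of compound 3 would keep growth inhibition near that of compound 3. For the compounds shown here, also open is whether the same change with a phenethyl group on the amide-type nitrogen would follow the step from compound 2 to compound 1 or the one from compound 3 to compound 4.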